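Sulfonamide series: aryl change on the sulfonyl sulfur

A few compounds are considered here, and "the series" means these few. Any claim that something is new, unique, unknown or untested is made for them only; others in the source may bear on it.

Compound 1 `C=Cc1ccc(S(=O)(=O)Nc2ccc3oc(-c4ccccc4)nc3c2)cc1` has been tested in an assay on isolated protein for inhibition of malate dehydrogenase, mitochondrial (Sus scrofa), with stated times of 45 min and 30 min; a lower number here means a stronger inhibitor, a higher number a weaker inhibitor. In this assay compound 1 gives only a limit, > 63000 nM. Compound 3 `O=S(=O)(Nc1ccc2oc(-c3ccccc3)nc2c1)c1ccc(C(F)(F)F)cc1` likewise gives only a limit in this assay, > 63000 nM. Compound 2 `CS(=O)(=O)Nc1ccc(-c2nc3ccccc3o2)cc1` also gives only a limit in this assay, > 63000 nM. Among the compounds with values here, the one measured step, a step that the two limits leave unreadable from compound 1 to compound 3, cannot be sized because of the limit of > 63000 nM in this assay, at which 3 of the 3 values shown sit. Compound 4 `COc1ccc(Cl)cc1S(=O)(=O)Nc1ccc2oc(-c3ccccc3)nc2c1` differs from compound 1 by 5-chloro-2-methoxyphenyl in place of 4-vinylphenyl on a sulfonyl sulfur. Within the data shown here, no measured step bears on this change, and the three values shown give no shift in this assay to read from. Compound 4 is expected to stay at the limit, with an estimated step from compound 1 of a step that the limit leaves unreadable from compound 1 to compound 4. The estimate for compound 4 is 90000 nM, ranging from 30000 nM to 300000 nM.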

Compound 4, half-maximal inhibitory concentration: > 63000 nM
Compound 4: no number, only a limit (the forecaster's own chance of this, stated with the estimate: 85%); the middle value is on the limit's open side.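

The step from compound 1 to compound 4 cannot be read, because both compounds give only a limit: the limit of > 63000 nM in this assay, at which 4 of the 4 values shown sit. The compounds shown leave open which change to the shared core, if any, would give a readable number in this assay.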